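Dimethylphenyl in Place of Methoxyphenyl: Compound 3 to Compound 4

The compounds below may be only part of what the source reports. "The series", "measured", "known", "first", "only" and "open" are said of these compounds alone.

Compound 1 `O=C(Nc1cccc(/C=C/C(=O)c2nc3ccccc3[nH]2)c1)c1ccccc1`: 2440 nM
Compound 2 `COc1cccc(C(=O)Nc2cccc(/C=C/C(=O)c3nc4ccccc4[nH]3)c2)c1`: 3680 nM
Compound 3 `COc1ccc(C(=O)Nc2cccc(/C=C/C(=O)c3nc4ccccc4[nH]3)c2)cc1`: 4880 nM

These three were measured in a functional assay on HCT-116 cells (Homo sapiens) for antiproliferative activity, read by MTT assay, with a stated time of 48 h; on this read-out higher numbers stand for weaker inhibition and lower numbers for stronger inhibition. Compound 3 stands at the top end of the three numbers, but the steps to the others are small: a 1.3-fold higher number from compound 2 to compound 3 (0.12 log units; within the scatter) and a 2.0-fold higher number from compound 1 to compound 3 (0.30 log units; within the scatter), both within the scatter. Compound 4 `Cc1cc(C)cc(C(=O)Nc2cccc(/C=C/C(=O)c3nc4ccccc4[nH]3)c2)c1` has not been measured; it differs from compound 3 by 3,5-dimethylphenyl in place of 4-methoxyphenyl on a carbonyl carbon. The measured steps that bear on this change all alter the same ring: a 1.5-fold higher number from compound 1 to compound 2 (0.18 log units; within the scatter) together with the two steps just named, none beyond the scatter. Exchanging one substituent pattern on this ring for another is therefore expected to leave this assay much as it was, with no step beyond the scatter. For compound 4 the estimate is 4000 nM, within a range of 1500 nM to 11000 nM, which means an expected step of a 1.2-fold lower number from compound 3 to compound 4 (0.09 log units; within the scatter).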

Compound 4, half-maximal inhibitory concentration: 1550 nM
Compound 4: the middle estimate sits 2.6-fold (0.41 log units) above what was measured; the measured number falls inside the stated range.
By their numbers in this assay, from the lowest: compounds 4, 1, 2 and 3 (each within the scatter of the next, the first and the last beyond it).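

In this assay the group on the carbonyl carbon can shift the number beyond the scatter, which the methoxy compounds alone did not show: 3,5-dimethylphenyl gives a 3.1-fold lower number from compound 3 to compound 4 (0.50 log units; beyond the scatter) and a 2.4-fold lower number from compound 2 to compound 4 (0.38 log units; beyond the scatter) as its two steps from the methoxyphenyl compounds. The change from plain phenyl gives only a 1.6-fold lower number from compound 1 to compound 4 (0.20 log units; within the scatter) and so sets no order between those two compounds. Nothing here explains the difference between dimethylphenyl and methoxyphenyl.

As far as these compounds go, whether a single methyl group would do the same remains open. So does the outcome with a chlorine or an amine on this ring.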